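Oxygen for sulfur in the aryl linker of compound 2

The compounds below may be only part of what the source reports. "The series", "measured", "known", "first", "only" and "open" are said of these compounds alone.

The study covers three compounds on a shared core. Compound 1 `Nc1cc(N)c2nc(-c3ccccc3)c(Oc3ccc(Cl)c(Cl)c3)nc2c1` carries a 3,4-dichlorophenoxy group on an aromatic carbon; in a functional assay on HCT-116 cells (Homo sapiens) for inhibition, read by sulforhodamine B assay, with a stated time of 48 h (on this read-out higher numbers stand for lower toxicity in this test and lower numbers for higher toxicity in this test), compound 1 gives only a limit, < 100000 nM. Among the measured compounds shown here, compound 2 `Nc1cc(N)c2nc(-c3ccccc3)c(Sc3ccc(F)cc3)nc2c1` carries (4-fluorophenyl)sulfanyl in that place, and in this assay compound 2 gives 55000 nM, the only number in the set. The step that the limit leaves unreadable from compound 1 to compound 2 cannot be sized, since the limit of < 100000 nM in this assay, at which 1 of the 2 values shown sits, hides where compound 1 truly sits.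

Compound 3 `Nc1cc(N)c2nc(-c3ccccc3)c(Oc3ccc(F)cc3)nc2c1` has not been measured. It differs from compound 2 by one change: 4-fluorophenoxy in place of (4-fluorophenyl)sulfanyl on an aromatic carbon. For the measured compounds named here, the single measured step in this set cannot be read, so no measured step bears on the size of this change, and nothing in the data points to a move beyond the usual scatter in either direction. Compound 3 is therefore expected to stay close to compound 2, with an estimated step of no change at the digits printed from compound 2 to compound 3 (within the scatter). In this assay compound 3 is estimated at 55000 nM, with a range from 20000 nM to 150000 nM.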

Compound 3, concentration lethal to 50% of the cells: < 100000 nM
Compound 3: no number, only a limit; the forecaster's own chance of this, stated with the estimate: 30%; the middle value lies beyond the limit too.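

In this assay compound 3 gives < 100000 nM as a limit and not a number. No new step can be read from compound 2 to compound 3 or from compound 1 to compound 3, because the values rest on a limit: the limit of < 100000 nM in this assay, at which 2 of the 3 values shown sit. The compounds shown leave open how far 4-fluorophenoxy in place of (4-fluorophenyl)sulfanyl moves the lethal concentration, and where compound 1 and compound 3 truly sit.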